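Two Growth Inhibitors and a Missing Methoxy

The source may hold more compounds than are shown below. What is called first, only, known or untested is meant among the compounds shown, and "the series" means these compounds.

Compound 1 `O=C1Nc2ccccc2C1=Cc1c(-c2ccncc2)nc2sccn12`: 2650 nM
Compound 2 `COc1ccc2c(c1)/C(=C\c1c(OC)nc3sc(C)cn13)C(=O)N2`: 430 nM

Both compounds were tested in a functional assay on cells (Leukemia cell, Homo sapiens) for cytotoxicity, read by sulforhodamine B assay, with a stated time of 48 h; a lower number here means a stronger inhibitor of growth, a higher number a weaker inhibitor of growth. Of the two, compound 2 gives the lower number, at 430 nM, and its gap to compound 1, at 2650 nM, lies beyond the usual scatter. Compound 2 is therefore the stronger inhibitor of growth of this pair, although two compounds give only a narrow view.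

The next compound, compound 3 `COc1nc2sc(C)cn2c1/C=C1/C(=O)Nc2ccccc21`, departs from compound 2 in one place: hydrogen in place of methoxy on an aromatic carbon. In words, this is hydrogen in place of methoxy on an aromatic carbon. Going by the values given here, no measured pair differs in one place only, so the data offer no direct guide to the size of this change. The starting point is compound 2 at 430 nM, and a modest move towards a weaker inhibitor of growth seems the more likely direction. The expected change is a 1.6-fold higher number from compound 2 to compound 3 (0.21 log units; within the scatter), small enough that it may stay within the scatter. For compound 3 the estimated value is 700 nM, with an expected range of 250 nM to 2000 nM.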

Compound 3, concentration for 50% growth inhibition: 500 nM
Compound 3: middle estimate off by 1.4-fold (0.15 log units), on the high side; low and high end bracket the measured number.
By their numbers in this assay, from the lowest: compounds 2 and 3 (each within the scatter of the next); then compound 1.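

In this assay, going by these compounds alone, the step of a 1.2-fold higher number from compound 2 to compound 3 (0.07 log units; within the scatter) comes with hydrogen in place of methoxy on an aromatic carbon of the six-membered aromatic ring of carbon only, and it is the first comparison here between compounds that differ in one place. It shows that, in this pair, the methoxy group at this position can give way to hydrogen with no change that this read-out can separate from the usual scatter, so the group is not needed to hold the growth inhibition of compound 2 at this level. No measurement at hand speaks to why the two compounds read alike.

On these data alone, what remains open is whether this tolerance extends to other groups on the same carbon, such as a fluorine atom, a hydroxyl, an amine or a longer alkoxy chain, or whether any of these would shift the number beyond the scatter. Compound 1 differs from compound 2 and compound 3 in more than one place, so the compounds shown also leave open which of those other differences bear on growth inhibition.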